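Ring closure of the amine side chain on the dioxolane series

The source may report more compounds than this note shows. Statements on the series, on what has been measured and on what is new or still open speak of the compounds shown alone.

Compound 2 `CCN[C@@H](C)[C@H]1COC(c2ccccc2)(c2ccccc2)O1` gives 9000 nM in a functional assay (brain) for displacement of a labelled ligand, with Rattus norvegicus as the target (a lower number here means a stronger inhibitor, a higher number a weaker inhibitor), the higher of the two numbers measured; compound 1 `CNC[C@H]1COC(c2ccccc2)(c2ccccc2)O1` gives 7300 nM, and the step of a 1.2-fold higher number from compound 1 to compound 2 (0.09 log units; within the scatter) lies within the scatter. Compound 3 `c1ccc(C2(c3ccccc3)OC[C@H]([C@@H]3CCCN3)O2)cc1` differs from compound 2 by pyrrolidin-2-yl in place of 1-(ethylamino)ethyl on a saturated ring carbon. Within the data shown here, the only step at this position, from compound 1 to compound 2, changed the number little, and no measured step reports a ring closure of this kind. The expected step of a 1.3-fold lower number from compound 2 to compound 3 (0.11 log units; within the scatter) is therefore small, with no firm direction. Compound 3 is estimated at 7000 nM, range 2000 nM to 25000 nM.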

Compound 3, inhibition constant: > 10000 nM
Compound 3 gave a limit, no number; the forecaster's own chance of this, stated with the estimate: 10%; middle value at least 1.4-fold (0.15 log units) from the limit.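

Compound 3 gives > 10000 nM in this assay, which is a limit of the assay and not a number. For pyrrolidin-2-yl, the only ring shown at this position, the steps read an at least 1.1-fold higher number from compound 2 to compound 3 (0.04 log units; that floor lies within the scatter) and an at least 1.3-fold higher number from compound 1 to compound 3 (0.13 log units; that floor lies within the scatter), so the ring gives no stronger reading than either open chain, and the true size of the step stays unknown. Only compound 3 sits at a limit: the limit of > 10000 nM in this assay, at which 1 of the 3 values shown sits.

Open, from the compounds shown here alone, is whether a six-membered piperidin-2-yl ring or a primary aminomethyl group on the same carbon would give a number in this assay.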